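The source may report more compounds than this note shows. Statements on the series, on what has been measured and on what is new or still open speak of the compounds shown alone.

Measured in a functional assay on PC-3 cells (Homo sapiens), read by MTT assay, with a stated time of 48 h; a higher number here means a weaker inhibitor, a lower number a stronger inhibitor:
- compound 1 `CCn1c(C(=O)NCCCN(C)C)ccc1C(CC)(CC)c1ccc(OCC(O)C(C)(C)C)c(C)c1`: 3100 nM
- compound 2 `CCn1c(C(=O)N(C)CCC#N)ccc1C(CC)(CC)c1ccc(OCC(O)C(C)(C)C)c(C)c1`: 1700 nM

Compound 2, at 1700 nM, cannot be separated from compound 1 in this assay, since the two values lie within the scatter of each other. The next compound to be tested is compound 3 `CC[C@@H](C)[C@H](NC(=O)c1ccc(C(CC)(CC)c2ccc(OCC(O)C(C)(C)C)c(C)c2)n1CC)C(=O)O`. The change is (1-carboxy-2-methylbutyl)amino in place of (2-cyanoethyl)(methyl)amino on a carbonyl carbon.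

Among the compounds with values here, only one measured step bears on this, a 1.8-fold lower number from compound 1 to compound 2 (0.26 log units; within the scatter), which swaps the group at the same carbonyl carbon and stays small. Within the data shown here, no measured compound carries a carboxy group, so that step is weak guidance and the range must stay wide. The expected change is a 1.4-fold higher number from compound 2 to compound 3 (0.15 log units; within the scatter), with no shift beyond the scatter anticipated. For compound 3 the estimated value is 2400 nM, with an expected range of 600 nM to 9000 nM.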

Compound 3, half-maximal inhibitory concentration: 1900 nM
Estimate against measurement, compound 3: 1.3-fold (0.10 log units) above; the measured number falls inside the stated range.
By their numbers in this assay, from the lowest: compounds 2, 3 and 1 (each within the scatter of the next).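

In this assay, (1-carboxy-2-methylbutyl)amino in place of (2-cyanoethyl)(methyl)amino on the carbonyl carbon gives a 1.1-fold higher number from compound 2 to compound 3 (0.05 log units; within the scatter), and 1-carboxy-2-methylbutyl in place of 3-(dimethylamino)propyl on the amide-type nitrogen gives a 1.6-fold lower number from compound 1 to compound 3 (0.21 log units; within the scatter). With a carboxy group now included, this position has carried groups bearing a dimethylamino, a nitrile and a carboxy group, and no pair among these three compounds separates beyond the scatter. No measurement available here accounts for this flat picture.

Going by these compounds, it remains open whether a methyl ester of the carboxylic acid, or a morpholine amide at the same carbonyl carbon, would move the number beyond the scatter. The role of the two defined stereocentres in the 1-carboxy-2-methylbutyl group also remains open, as the opposite configurations do not appear among these compounds.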